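A Ring Swap on the Ether Oxygen of Compound 1

A few compounds are considered here, and "the series" means these few. Any claim that something is new, unique, unknown or untested is made for them only; others in the source may bear on it.

Measured compounds:
Compound 1, `Cc1cc(Cl)cc(-c2ccnc3cc(CN4C(=O)CCC4=O)sc23)c1O[C@H]1CCCNC1`: 180 nM
Compound 2, `Cc1cc(Cl)cc(-c2ccnc3cc(CN4C(=O)C5CC5C4=O)sc23)c1C[C@@H]1CNCCO1`: 35 nM

Of the compounds shown here, two have been measured in an assay on RKO cells for inhibition of ubiquitin carboxyl-terminal hydrolase 7 (Homo sapiens), read by a luciferase reporter, with a stated time of 18 h; a higher number here means that more compound is needed for the effect, a lower number that less compound is needed. Compound 1, with structure `Cc1cc(Cl)cc(-c2ccnc3cc(CN4C(=O)CCC4=O)sc23)c1O[C@H]1CCCNC1`, gives 180 nM in this assay, the highest of the two numbers. Compound 2, with structure `Cc1cc(Cl)cc(-c2ccnc3cc(CN4C(=O)C5CC5C4=O)sc23)c1C[C@@H]1CNCCO1`, gives 35 nM, a gap beyond the usual scatter. The two compounds differ in several places at once, so the shown values say nothing about any single change.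

Compound 3, with structure `Cc1cc(Cl)cc(-c2ccnc3cc(CN4C(=O)CCC4=O)sc23)c1O[C@@H]1CCNC[C@@H]1C`, has not yet been measured. It differs from compound 1 in one place: 3-methylpiperidin-4-yl in place of piperidin-3-yl on an oxygen on an aromatic ring. Among the compounds with values here, no pair of measured compounds shows the effect of such a change, so there is no measured step to lean on. Given that, the expectation is a step that stays close to the scatter, with no clear direction. For compound 3 the estimated value in this assay is 150 nM, with a range from 50 nM to 500 nM. This estimate corresponds to an expected step of a 1.2-fold lower number from compound 1 to compound 3 (0.08 log units; within the scatter).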

Compound 3, half-maximal effective concentration: 150 nM
For compound 3 middle estimate and measured number coincide at the digits printed; low and high end bracket the measured number.
By their numbers in this assay, from the lowest: compound 2; then compounds 3 and 1 (each within the scatter of the next).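

In this assay, within the data shown here, placing 3-methylpiperidin-4-yl in place of piperidin-3-yl on an oxygen on an aromatic ring gives a 1.2-fold lower number from compound 1 to compound 3 (0.08 log units; within the scatter), the first step here that can be read as a single change, since the other pair differs in several places at once. It shows that this group on the oxygen can be swapped for a ring with a different attachment point, an added methyl and a second defined stereocentre while the number stays within the usual scatter, so this particular change neither clearly helps nor clearly harms. No measurement at hand accounts for how close the two numbers lie.

The attachment point and the methyl changed together, so a plain piperidin-4-yl on the same oxygen would be needed to tell their separate contributions apart. As far as these compounds go, how far this tolerance extends also remains open, for instance to an open-chain 2-aminoethyl group or a group ending in a carboxylic acid, as one swap between two closely related rings says little about more distant replacements.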